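Swapping the Amide Aryl Group: From Fluorophenyl to Ethoxyphenyl

This account rests on a few compounds, and the source may have more. Where it says the series, first, only, none or still open, it means among the compounds named here.

Of the compounds shown here, three sharing one core have been measured so far. Compound 1 `COc1ccccc1C(=O)Nc1nc(-c2ccccc2)nc2c1nnn2Cc1ccccc1` carries a 2-methoxyphenyl on the carbonyl carbon and gives 1520 nM in an assay (strain Wistar) for displacement of a labelled ligand from adenosine receptor A1 (Rattus norvegicus), read by scintillation counting; a higher number here means a weaker inhibitor, a lower number a stronger inhibitor. Compound 2 `O=C(Nc1nc(-c2ccccc2)nc2c1nnn2Cc1ccccc1)c1ccoc1` carries a furan-3-yl there and gives 10 nM. Compound 3 `O=C(Nc1nc(-c2ccccc2)nc2c1nnn2Cc1ccccc1)c1cccc(F)c1` carries a 3-fluorophenyl and gives 22 nM, which places it second highest of the three numbers; the step of a 2.2-fold higher number from compound 2 to compound 3 (0.34 log units; beyond the scatter) is modest, while the step of a 69-fold lower number from compound 1 to compound 3 (1.84 log units; beyond the scatter) is large.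

Compound 4 `CCOc1ccccc1C(=O)Nc1nc(-c2ccccc2)nc2c1nnn2Cc1ccccc1` is the next to be measured. The change from compound 3 is 2-ethoxyphenyl in place of 3-fluorophenyl on a carbonyl carbon. The 2-ethoxyphenyl that enters closely resembles the 2-methoxyphenyl of compound 1, differing only in the 9 heavy atoms counted against the smaller group. The step that bears most directly on this change is a 69-fold lower number from compound 1 to compound 3 (1.84 log units; beyond the scatter), which ran strongly in the opposite direction. A large rise in the number is therefore expected, roughly undoing that step. Compound 4 is estimated at 1800 nM, within 500 nM to 6000 nM, an expected step of an 82-fold higher number from compound 3 to compound 4 (1.91 log units; beyond the scatter).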

Compound 4, inhibition constant: 1850 nM
Beside the measured number, compound 4's estimate is 1.0-fold (0.01 log units) below it; low and high end bracket the measured number.
By their numbers in this assay, from the lowest: compound 2; then compound 3; then compounds 1 and 4 (each within the scatter of the next).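

In this assay, the 2-ethoxyphenyl on the carbonyl carbon gives a number far from those of the two better groups: replacing 3-fluorophenyl gives an 84-fold higher number from compound 3 to compound 4 (1.92 log units; beyond the scatter), and replacing furan-3-yl gives a 190-fold higher number from compound 2 to compound 4 (2.27 log units; beyond the scatter). Extending the methoxy chain by one methyl gives a 1.2-fold higher number from compound 1 to compound 4 (0.09 log units; within the scatter), which lies within the scatter, so this assay cannot tell the 2-methoxyphenyl and 2-ethoxyphenyl groups apart, and the high number is now seen with two related groups rather than one. No measurement shown here explains why these two groups differ so much from the 3-fluorophenyl and furan-3-yl groups.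

The compounds shown leave open how a plain phenyl with no substituent would read in this assay. They also leave open whether a longer chain, such as propoxy, would read the same as the methoxy and ethoxy groups.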